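The source may hold more compounds than are shown below. What is called first, only, known or untested is meant among the compounds shown, and "the series" means these compounds.

Compound 1 `C=CCONC(=O)Cn1cc(C(=O)NCC(=O)N[C@H](C(=O)O)C(C)C)c2ccccc21` gives > 128000 nM in a functional assay on MRC5 cells (Homo sapiens) for inhibition, read by microscopy and resazurin assay, with a stated time of 72 h; a lower number here means a stronger inhibitor, a higher number a weaker inhibitor. Compound 2 `C=CCONC(=O)Cn1cc(C(=O)NCC(=O)N[C@@H](CC(C)C)C(=O)O)c2ccccc21` gives > 128000 nM in this assay. Compound 3 `CC(C)[C@H](NC(=O)[C@H](C)NC(=O)c1ccn(CC(=O)NOCc2ccccc2)c1)C(=O)O` gives > 128000 nM in this assay.

Each of these three values is a limit of the assay rather than a number, so the limit of > 128000 nM in this assay, at which 3 of the 3 values shown sit, is the whole of what is known about the measured set. The change isobutyl in place of isopropyl on a saturated chain carbon bound to an amide-type nitrogen and a carbonyl carbon is made from compound 1 to compound 2, and the step that the two limits leave unreadable from compound 1 to compound 2 cannot be read because the limit of > 128000 nM in this assay, at which 3 of the 3 values shown sit, caps both values. The core of compound 3 differs from the core of compound 1 in more than one place, and that difference is not broken down here.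

Compound 4 `CC(C)C[C@H](NC(=O)[C@H](C)NC(=O)c1ccn(CC(=O)NOCc2ccccc2)c1)C(=O)O` is not yet measured. For the measured compounds named here, it differs from compound 3 by isobutyl in place of isopropyl on a saturated chain carbon bound to an amide-type nitrogen and a carbonyl carbon, the same change as the one from compound 1 to compound 2, at a place described in identical words. The step from compound 3 to compound 4 is expected to be a step that the limit leaves unreadable from compound 3 to compound 4, because the limit of > 128000 nM in this assay, at which 3 of the 3 values shown sit, shows compound 3 at the limit and the earlier instance of this change left compound 2 at the same limit. Compound 4 is therefore estimated at 200000 nM, with a range from 100000 nM to 600000 nM, most likely reported only as a limit.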

Compound 4, half-maximal inhibitory concentration: > 128000 nM
Compound 4: a limit, no number (the forecaster's own chance of this, stated with the estimate: 85%); the middle value does not contradict the limit.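

No step can be read from compound 3 to compound 4, and the isobutyl in place of isopropyl stays without a size, because the only result is a limit of the assay and not a number: the limit of > 128000 nM in this assay, at which 4 of the 4 values shown sit.

The compounds shown leave open what inhibitory concentration any of them has in this assay, and whether this change alters it at all.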